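Methoxy in place of fluoro on the aromatic ring

The source may hold more compounds than are shown below. What is called first, only, known or untested is meant among the compounds shown, and "the series" means these compounds.

In a physicochemical assay for solubility, using the shake flask method, in simulated intestinal fluid, measured as kinetic solubility, with a stated time of 2 h, at 25 degrees C, at pH 6.5 (on this read-out higher numbers stand for higher solubility and lower numbers for lower solubility), compound 1 `Cc1noc(-c2nc(C)c3c(c2N)C(=O)N(CC2CCOCC2)C3=O)n1` gives 5700 nM. Compound 2 `Cc1noc(-c2nc(C)c3c(c2N)C(=O)N(Cc2ccccc2F)C3=O)n1` has only a limit, < 5000 nM, and no number. Compound 3 `COc1ccccc1CN1C(=O)c2c(C)nc(-c3nc(C)no3)c(N)c2C1=O` carries methoxy in place of fluoro on an aromatic carbon, ortho to a large group (methoxy in place of fluoro on an aromatic carbon). Among the compounds with values here, the only measured step bearing on this is an at least 1.1-fold lower number from compound 1 to compound 2 (0.05 log units; that floor lies within the scatter), which replaces a whole group and gives only a floor for its size. No step beyond the scatter is therefore expected, and the estimated step is a step that the limit leaves unreadable from compound 2 to compound 3. In this assay, the estimated value for compound 3 is 4000 nM, expected between 1500 nM and 9000 nM.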

Compound 3, solubility: < 5000 nM
Compound 3 was reported as a limit; the forecaster's own chance of this, stated with the estimate: 65%; the middle value is on the limit's open side.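

In this assay compound 3 is reported only as a limit, < 5000 nM, not as a number. Compound 2 also carries a limit, so the step between them cannot be read, and both the fluoro and the methoxy compound end at the same limit: the limit of < 5000 nM in this assay, at which 2 of the 3 values shown sit. The 2-methoxyphenyl group in place of oxan-4-yl gives an at least 1.1-fold lower number from compound 1 to compound 3 (0.05 log units; that floor lies within the scatter).

As far as these compounds go, how far compound 2 and compound 3 actually lie under that limit remains open. So does whether an amine or a carboxylic acid on this aromatic carbon would give a readable number in this assay.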